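Thiophene to difluorophenyl on the amide carbonyl of the core

The source may report more compounds than this note shows. Statements on the series, on what has been measured and on what is new or still open speak of the compounds shown alone.

Compound 1 `CC(C)OC(=O)C1=CN(C(=O)c2cccs2)CC(C)(C)c2cc(C#N)[nH]c21` carries a thiophen-2-yl group on a carbonyl carbon of the shared core. In an assay on HEK293 cells for agonist activity at Bile acid receptor (Homo sapiens), read by a luciferase reporter (a lower number here means a smaller maximal response, a higher number a larger maximal response), compound 1 gives 114%. Two other compounds share that core: compound 2 `CC(C)OC(=O)C1CN(C(=O)C2CCCCC2)CC(C)(C)c2cc(C#N)[nH]c21`, which in this assay gives 127%, and compound 3 `CC(C)OC(=O)C1CN(C(=O)c2ccc(Cl)cc2)CC(C)(C)c2cc(C#N)[nH]c21`, which in this assay gives 115%. The value of compound 1 lies within the scatter of compound 3, while compound 2 stands beyond the scatter above compound 1.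

Compound 4 `CC(C)OC(=O)C1=CN(C(=O)c2ccc(F)c(F)c2)CC(C)(C)c2cc(C#N)[nH]c21` has not yet been measured. It differs from compound 1 in one place: 3,4-difluorophenyl in place of thiophen-2-yl on a carbonyl carbon. For the measured compounds named here, the only measured step at this position is a number 12 percentage points lower from compound 2 to compound 3 (beyond the scatter), where cyclohexyl gave way to 4-chlorophenyl. The present change keeps an aromatic ring on the carbonyl carbon, and compound 3, which also carries a halogenated phenyl there, sits within the scatter of compound 1. The expected outcome is therefore a number 1 percentage points higher from compound 1 to compound 4 (within the scatter), a step not beyond the scatter. Compound 4 is estimated to give 115% in this assay, with a range from 100% to 130%.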

Compound 4, largest response reached (reported as efficacy), in percent of the reference or control that the assay uses: 121%
Compound 4: middle estimate off by 6 percentage points, on the low side, within the range that was stated.
By their numbers in this assay, from the lowest: compounds 1, 3, 4 and 2 (each within the scatter of the next, the first and the last beyond it).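

In this assay, the exchange on the carbonyl carbon gives a number 7 percentage points higher from compound 1 to compound 4 (within the scatter), the first step read directly on compound 1. A five-membered aromatic ring containing sulfur and a larger six-membered carbon-only ring bearing two fluorines can therefore replace each other here with no change beyond the usual scatter, so this exchange leaves the maximal response effectively unchanged. No measurement is available that could explain this result, so the step stands only as an observation.

As far as these compounds go, it remains open whether a phenyl ring with only one fluorine would behave the same way at this position. Also unresolved is how a pyridin-3-yl ring, or a phenyl ring carrying a carboxylic acid, would fare on the same carbonyl carbon.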